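Chloropyridine positional swap in the pyrazolopyridinone series

This account rests on a few compounds, and the source may have more. Where it says the series, first, only, none or still open, it means among the compounds named here.

Measured compounds, in an assay on Raji cells for inhibition of Monocarboxylate transporter 1 (Homo sapiens), read by MTT assay, with a stated time of 96 h; on this read-out lower numbers stand for an effect already at smaller amounts and higher numbers for an effect only at larger amounts of compound:
compound 1 `CC(C)Cc1nn(C)c(=O)c2c(SCCCO)n(Cc3ccc(NCCCCCN)nc3)cc12` gives 420 nM
compound 2 `CC(C)Cc1nn(C)c(=O)c2c(SCCCO)n(Cc3ccnc(NCCCCCN)c3)cc12` gives 520 nM
compound 3 `CC(C)Cc1nn(C)c(=O)c2c(SCCCO)n(Cc3ccnc(Cl)c3)cc12` gives 1000 nM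

Compound 3 has the highest of the three numbers in this assay. Its nearest neighbour is compound 2, and the step of a 1.9-fold higher number from compound 2 to compound 3 (0.28 log units; within the scatter) is within the scatter. Compound 1 lies further off, beyond the scatter.

Compound 4 `CC(C)Cc1nn(C)c(=O)c2c(SCCCO)n(Cc3ccc(Cl)nc3)cc12` is not yet measured. It differs from compound 3 by 6-chloropyridin-3-yl in place of 2-chloropyridin-4-yl on a saturated chain carbon bound to an aromatic nitrogen. Going by the values given here, no measured step covers this exact change. The closest comparison is the pair compound 1 and compound 2, where the same two ring attachment patterns carry the (5-aminopentyl)amino group in place of chlorine: compound 1 gives 420 nM and compound 2 gives 520 nM, which lie within the scatter of each other. On that basis the step of a 1.1-fold lower number from compound 3 to compound 4 (0.05 log units; within the scatter) is expected to be small, with no clear direction beyond the scatter. Compound 4 is therefore estimated at 900 nM in this assay, with a range from 450 nM to 1800 nM.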

Compound 4, half-maximal effective concentration: 690 nM
Compound 4: middle estimate off by 1.3-fold (0.12 log units), on the high side; the range from low to high includes it.
By their numbers in this assay, from the lowest: compounds 1, 2, 4 and 3 (each within the scatter of the next, the first and the last beyond it).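

With chlorine on the ring, the attachment swap at this saturated chain carbon bound to an aromatic nitrogen gives, in this assay, a 1.4-fold lower number from compound 3 to compound 4 (0.16 log units; within the scatter), so this pair, like the aminopentylamino pair before it, does not separate the two ring patterns. The exchange of (5-aminopentyl)amino for chloro can now be read on the 6-substituted pyridin-3-yl pattern as well, as a 1.6-fold higher number from compound 1 to compound 4 (0.22 log units; within the scatter), so on neither pattern does this exchange alone reach beyond the scatter. The exchange reads alike on both patterns: the same change on two cores in this assay, a 1.9-fold higher number (0.28 log units; within the scatter) from compound 2 to compound 3 and a 1.6-fold higher number (0.22 log units; within the scatter) from compound 1 to compound 4, 1.2-fold (0.07 log units) apart, within the scatter of two such steps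

Whether any group on the pyridine ring matters at this position stays open, since all the single-place steps shown remain within the scatter. A carboxylic acid or a plain phenyl ring in place of the chloropyridine would test how far this tolerance extends.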